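The source may hold more compounds than are shown below. What is called first, only, known or untested is meant among the compounds shown, and "the series" means these compounds.

The study follows two measured compounds and one that awaits measurement. Compound 1, `CNC(=O)c1cc(C(=O)N[C@H]2[C@@H]3C[C@H](O)C[C@@H]32)n([C@@H](C)c2cccc(Cl)c2)n1`, is tested in an ADME assay on cells (Hepatocyte, Rattus norvegicus, strain Wistar han) for metabolic stability, read by LC-MS, with a stated time of 60 min (a higher number here means faster removal of the compound, a lower number slower removal), where compound 1 gives 17.3 mL/min. Compound 2, `CNC(=O)c1cc(C(=O)N[C@H]2CC[C@H](O)CC2)c([C@@H](C)c2ccccc2)o1`, gives in this assay a value of 0.8 mL/min, so compound 1 stands as the higher of the two numbers recorded, and the gap between compound 1 and compound 2 lies beyond the usual scatter of the measurement. Within the data shown here, no direct step between compound 1 and compound 2 is worked out, since the two differ in several places at once.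

The compound still to be measured, compound 3, `CNC(=O)c1cc(C(=O)N[C@H]2[C@@H]3C[C@@H](O)C[C@@H]32)n([C@@H](C)c2cccc(Cl)c2)n1`, is drawn as a close relative of compound 1. The difference is confined to one point: the two compounds have the same atoms and bonds and differ only in configuration as drawn: 1 of 5 stereo elements differ; a stereocentre at a saturated ring carbon is drawn S in compound 1 and R in compound 3

Among the measured compounds shown here, no measured pair in this set records the effect of such a change. The expectation rests on compound 1 alone. The step from compound 1 to compound 3 in this assay is expected to be small, in no particular direction, and not beyond the scatter, amounting to a 1.2-fold lower number from compound 1 to compound 3 (0.06 log units; within the scatter). For compound 3 in this assay the estimated value is 15 mL/min, with a range from 7 mL/min to 35 mL/min.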

Compound 3, intrinsic clearance in a liver preparation (reported as CLH), per the amount of preparation that the assay uses in the Hepatocyte assay: 1 mL/min
For compound 3 the middle estimate is 15-fold (1.18 log units) above the measured one; measured number below the stated range.
By their numbers in the Hepatocyte assay, from the lowest: compounds 2 and 3 (each within the scatter of the next); then compound 1.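

Turning this one stereocentre from S to R gives a 17-fold lower number from compound 1 to compound 3 (1.24 log units; beyond the scatter) in the Hepatocyte assay, so configuration alone at this saturated ring carbon can carry a large step, which the earlier measured compounds, differing in several places at once, could not show. In a physicochemical assay for lipophilicity (on this read-out higher numbers stand for higher lipophilicity and lower numbers for lower lipophilicity), compound 1 gives 3.7 and compound 3 gives 3.4, two values within the scatter of each other, so this read-out shows no separation to match the step in removal. The large step can be assigned to this single stereocentre because nothing else separates the two structures: the fact that compounds 1 and 3 differ only in the configuration as drawn

The compounds shown leave open whether the same inversion would bring a step of similar size on a different core or with a different aryl group on the shared core, and they do not tell by what route compound 1 is removed faster. They also leave open how an amine or a methoxy group in place of the hydroxyl group would stand in the Hepatocyte assay, in either configuration.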